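The source may hold more compounds than are shown below. What is called first, only, known or untested is meant among the compounds shown, and "the series" means these compounds.

Working notes on the series. Compound 1 `COCc1cc(C#N)cc(-c2ccc3ccc(C)nc3c2)c1` and compound 2 `COc1cc(C#N)cc(-c2ccc3ccc(C)nc3c2)c1` share the core and differ only at one aromatic carbon. In a functional assay on CHO cells for inhibition of metabotropic glutamate receptor 5 (Rattus norvegicus), read by FLIPR and calcium flux (a lower number here means a stronger inhibitor, a higher number a weaker inhibitor), compound 1 gives 2 nM. In this assay compound 2 gives 2.4 nM. For the measured compounds named here, the single measured step, a 1.2-fold higher number from compound 1 to compound 2 (0.08 log units; within the scatter), is methoxy in place of methoxymethyl on an aromatic carbon, and it falls within the scatter. Going by the values given here, compound 2 therefore stands at the highest of the two numbers so far, yet not separated from compound 1 beyond the scatter.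

The next step goes to compound 3 `Cc1ccc2ccc(-c3cc(Br)cc(C#N)c3)cc2n1`. The change is bromo in place of methoxy on an aromatic carbon: bromo in place of methoxy, on an aromatic carbon of a six-membered aromatic ring of carbon only, meta to a cyano group and meta to a large group. Among the compounds with values here, the one measured step bears on it only loosely, since it swapped two oxygen-bearing groups at this carbon without moving the number beyond the scatter; nothing measured yet shows a halogen here. The working expectation for compound 3 in this assay is a step of a 1.7-fold higher number from compound 2 to compound 3 (0.22 log units; within the scatter), a small change that may not exceed the scatter. Compound 3 is therefore estimated at 4 nM, with a range from 1.5 nM to 12 nM.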

Compound 3, half-maximal inhibitory concentration: 13 nM
Compound 3: middle estimate off by 3.3-fold (0.51 log units), on the low side; measured number outside the range, above it.
By their numbers in this assay, from the lowest: compounds 1 and 2 (each within the scatter of the next); then compound 3.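

At the aromatic carbon meta to a cyano group and meta to a large group, the number in this assay does respond to the substituent: replacing methoxy with bromo gives a 5.4-fold higher number from compound 2 to compound 3 (0.73 log units; beyond the scatter) and replacing methoxymethyl with bromo gives a 6.5-fold higher number from compound 1 to compound 3 (0.81 log units; beyond the scatter) and both steps are modest. For the compounds shown here, the earlier pair showed only that methoxy and methoxymethyl stand within the scatter of each other, so this is the first change at this carbon that moves the number beyond the scatter, and it leaves compound 3 as the weakest inhibitor of the three. No measured evidence on the series explains why bromo differs from the other two groups at this carbon.

With a single halogen at this carbon, the compounds shown leave open whether the weaker result belongs to bromo alone or would also appear with chloro, fluoro or a plain methyl group. They also leave open how an amine, a carboxylic acid or a longer alkoxy chain such as ethoxy would compare with methoxy and methoxymethyl at the same carbon on the shared core.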